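Furan-to-thiophene swap on the shared core

This account rests on a few compounds, and the source may have more. Where it says the series, first, only, none or still open, it means among the compounds named here.

In an assay for inhibition of Tryptophan 2,3-dioxygenase (Homo sapiens), with a stated time of 1 h, tested at 10 uM (a higher number here means more inhibition at the concentration tested (going by the name of the read-out), a lower number less inhibition), compound 3 `Brc1cc(NCc2ccco2)c2cn[nH]c2c1` gives 64%. Compound 1 `Nc1ccc(CNc2cc(Br)cc3[nH]ncc23)cc1` gives 24% in this assay, a gap that lies beyond the scatter, so compound 3 stands highest of the two numbers available. Compound 2 `Oc1ccc(CNc2cc(Br)cc3[nH]ncc23)cc1O` is reported in this assay as "not active" (no number reported), without a number. Compound 4 `Brc1cc(NCc2cccs2)c2cn[nH]c2c1` has not yet been measured; it differs from compound 3 by thiophen-2-yl in place of furan-2-yl on a saturated chain carbon bound to a nitrogen on an aromatic ring. Going by the values given here, no step between measured compounds covers this kind of change, so the exchange carries no precedent here. The expectation is that the step of a number 4 percentage points lower from compound 3 to compound 4 (within the scatter) stays within the scatter, with no clear direction either way. Compound 4 is therefore estimated at 60% in this assay, within a range from 40% to 80%.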

Compound 4, a percentage reported as inhibition, at one concentration (the size of the read-out at that concentration, not a potency): 53%
The estimate for compound 4 lay 7 percentage points above the measured number; the measured number falls inside the stated range.
By their numbers in this assay, from the lowest: compound 1; then compound 4; then compound 3.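

In this assay, thiophen-2-yl in place of furan-2-yl on a saturated chain carbon bound to a nitrogen on an aromatic ring gives a number 11 percentage points lower from compound 3 to compound 4 (beyond the scatter), the first single-place exchange readable in this series. The position therefore distinguishes between these two five-membered aromatic rings, though only modestly, and inhibition remains measurable with either. Nothing available explains the step.

Still open, going by these compounds, is how a pyridin-2-yl ring or a saturated cyclopentyl group would read in this position. Equally open, on these data alone, is the effect of a longer chain carrying the furan-2-yl ring.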